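Methoxy to hydroxy on the aryl ring: compound 3

A few compounds are considered here, and "the series" means these few. Any claim that something is new, unique, unknown or untested is made for them only; others in the source may bear on it.

Measured compounds:
Compound 1 `COC(=O)C1=C(C)N=C(C)/C(=C(/O)OC)C1c1cccc(N/C(=N/CCNC2CCN(c3ccccc3C)CC2)NC#N)c1` gives 4 nM in an assay on SK-N-MC cells for inhibition of Neuropeptide Y receptor type 1 (Homo sapiens); on this read-out lower numbers stand for stronger inhibition and higher numbers for weaker inhibition.
Compound 2 `COC(=O)C1=C(C)N=C(C)/C(=C(/O)OC)C1c1cccc(N/C(=N/CCNC2CCN(c3ccccc3OC)CC2)NC#N)c1` gives 4 nM in this assay.

Compound 2 stands level with compound 1 on these numbers; the step of no change at the digits printed from compound 1 to compound 2 (within the scatter) shows that swapping methyl for methoxy on that aromatic carbon left the potency unchanged within the scatter. Compound 3 `COC(=O)C1=C(C)N=C(C)/C(=C(/O)OC)C1c1cccc(N/C(=N/CCNC2CCN(c3ccccc3O)CC2)NC#N)c1` carries the change (hydrogen in place of methyl on an oxygen on an aromatic ring), so the 2-methoxyphenyl becomes a 2-hydroxyphenyl. Among the measured compounds shown here, no measured step touches this oxygen directly, so the only guide is the tolerance of the same ring position seen in no change at the digits printed from compound 1 to compound 2 (within the scatter). On that basis compound 3 is expected to show little or no shift beyond the scatter, a 1.5-fold higher number from compound 2 to compound 3 (0.18 log units; within the scatter), with a modest loss left open. The estimate for compound 3 in this assay is 6 nM, within 2 nM to 20 nM.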

Compound 3, half-maximal inhibitory concentration: 5 nM
Estimate against measurement, compound 3: 1.2-fold (0.08 log units) above; measured number inside the range.
By their numbers in this assay, from the lowest: compounds 1, 2 and 3 (each within the scatter of the next).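

In this assay, taking the methyl off the oxygen to turn methoxy into hydroxy gives a 1.3-fold higher number from compound 2 to compound 3 (0.10 log units; within the scatter) and so leaves potency within the scatter. Set against the methyl group of the first compound in the series, hydroxy gives a 1.3-fold higher number from compound 1 to compound 3 (0.10 log units; within the scatter) and also stays within the scatter, so this aromatic carbon has now carried methyl, methoxy and hydroxy with no difference beyond the scatter. Nothing available here explains why these three groups read alike.

Going by these compounds, whether the same holds for an amine, a carboxylic acid or a longer alkoxy chain at this carbon remains open. The three compounds also share the rest of their structure, so they cannot show whether these groups would read alike on a different core.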